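The source may report more compounds than this note shows. Statements on the series, on what has been measured and on what is new or still open speak of the compounds shown alone.

Measured so far in a functional assay on U-373MG ATCC cells (Homo sapiens) for inhibition, read by colorimetric assay and MTT assay, with a stated time of 72 h (a higher number here means a weaker inhibitor, a lower number a stronger inhibitor), are these compounds:
compound 1 `Cc1ccc2c(c1)-c1cnc(n1C)OCCCCCCCCO2` – 57000 nM
compound 2 `C=CCCCCOc1ccccc1-c1cnc(OCCCC=C)n1C` – 5000 nM

Of these two, compound 2 holds the lower number and is the stronger inhibitor, and its gap to compound 1 lies beyond the usual scatter. The next compound, compound 3 `C=CCCCCOc1ccccc1-c1cnc(S(=O)(=O)c2ccccc2)n1C`, differs from compound 2 in one place: phenylsulfonyl stands in place of (pent-4-en-1-yl)oxy on an aromatic carbon (phenylsulfonyl in place of (pent-4-en-1-yl)oxy on an aromatic carbon). That carbon lies between two ring nitrogen atoms. Among the measured compounds shown here, no measured pair shows what such an exchange does in this assay and the expectation is therefore loose: a moderate step toward a higher number, meaning a somewhat weaker inhibitor, that may only just clear the scatter. The expected move is a 2.4-fold higher number from compound 2 to compound 3 (0.38 log units; beyond the scatter) and it is only an estimate. For compound 3 the estimated value is 12000 nM (expected range from 3000 nM to 50000 nM).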

Compound 3, half-maximal inhibitory concentration: 63000 nM
Compound 3: the middle estimate sits 5.3-fold (0.72 log units) below what was measured; measured number outside the range, above it.
By their numbers in this assay, from the lowest: compound 2; then compounds 1 and 3 (each within the scatter of the next).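

In this assay, this aromatic carbon between two ring nitrogen atoms proves sensitive to what it carries: phenylsulfonyl in place of (pent-4-en-1-yl)oxy gives a 13-fold higher number from compound 2 to compound 3 (1.10 log units; beyond the scatter). Among the compounds shown here, the single exchange removes an open chain with one double bond and an oxygen link, and brings in a six-membered aromatic ring on a sulfonyl group, so this one step cannot show which of these features accounts for the higher number. Nothing shown explains the size of the step.

The compounds shown leave open whether phenoxy or methylsulfonyl, each keeping only part of the entering group, would stay close to compound 2 or compound 3. They also leave open how a shorter methoxy group, a longer alkoxy chain or an amine would fare on this carbon.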